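Benzyloxy to hydroxy on the aryl oxime series

A few compounds are considered here, and "the series" means these few. Any claim that something is new, unique, unknown or untested is made for them only; others in the source may bear on it.

Three analogues of the shared core have been measured so far. Compound 1 `O/N=C(\CCN1CCN(c2ccccn2)CC1)c1ccc(Cl)cc1` gives 46% in a functional assay on HEK293 cells with D(4) dopamine receptor (Homo sapiens) as the target, read by FLIPR; on this read-out lower numbers stand for smaller maximal responses and higher numbers for larger maximal responses. Going by the values given here, compound 2 `O/N=C(\CCN1CCN(c2ccccn2)CC1)c1cc(F)cc(F)c1` gives 74% in this assay, and the single one-place step on record, a number 28 percentage points higher from compound 1 to compound 2 (beyond the scatter), concerns only the aromatic ring on the carbon with a double bond to nitrogen. Compound 3 `Cc1ccc(OCc2ccccc2)c(/C(CCN2CCN(c3ccccn3)CC2)=N/O)c1` gives 4% in this assay, the lowest of the three numbers: compound 1 and compound 2 both lie higher, beyond the scatter.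

Compound 4 `Cc1ccc(O)c(/C(CCN2CCN(c3ccccn3)CC2)=N/O)c1` has not yet been measured. It differs from compound 3 in one place: hydrogen in place of benzyl on an oxygen on an aromatic ring. Among the compounds with values here, no measured step covers this kind of change; the one step on record swaps ring substituents on a different part of the molecule, so it gives no direct guidance. The two compounds without a benzyloxy group, compound 1 and compound 2, sit well above compound 3, but neither is a one-place neighbour of compound 4, so their numbers can only hint at direction. For compound 4 the expected outcome in this assay is 25%, within 0% to 60%. The expected step from compound 3 to compound 4 is therefore a number 21 percentage points higher from compound 3 to compound 4 (beyond the scatter), upward, with low confidence.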

Compound 4, largest response reached (reported as efficacy), in percent of the reference or control that the assay uses: 73%
For compound 4 the middle estimate is 48 percentage points below the measured one; measured number above the stated range.
By their numbers in this assay, from the lowest: compound 3; then compound 1; then compounds 4 and 2 (each within the scatter of the next).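

In this assay, going by these compounds alone, hydrogen in place of benzyl on an oxygen on an aromatic ring gives the only measured step at this position (a number 69 percentage points higher from compound 3 to compound 4 (beyond the scatter)), and it is large, so the benzyloxy to hydroxy change counts for more here than either ring swap on record. With the hydroxy group in place, the 2-hydroxy-5-methylphenyl ring cannot be told apart from the 3,5-difluorophenyl ring (a number 1 percentage points lower from compound 2 to compound 4 (within the scatter)) and stands clear of the 4-chlorophenyl ring (a number 27 percentage points higher from compound 1 to compound 4 (beyond the scatter)), so among these four compounds the low number belongs to the benzyloxy compound alone, not to the substituted ring that carries it. Nothing at hand explains the size of this step.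

The compounds shown leave open whether a methyl group on this oxygen would read closer to compound 3 or to compound 4, and whether an amine in place of the hydroxy would hold the number of compound 4. Also open, on these data alone, is whether benzyl on such an oxygen would bring a step of similar size on a ring with other substituents, since this pair offers a single example.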